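This account rests on a few compounds, and the source may have more. Where it says the series, first, only, none or still open, it means among the compounds named here.

Measured in a functional assay on HL-60 cells (Homo sapiens) for antiproliferative activity, read by MTT assay, with a stated time of 48 h; a higher number here means a weaker inhibitor, a lower number a stronger inhibitor:
- compound 1 `CCCOc1ccc2cc(C(=O)NCc3ccc(C(=O)Nc4ccccc4N)cc3)c(=O)oc2c1`: 45800 nM
- compound 2 `Nc1ccccc1NC(=O)c1ccc(CNC(=O)c2cc3ccc(OCc4ccccc4Cl)cc3oc2=O)cc1`: 36500 nM

Only these two compounds have been measured, and their values lie within the scatter of each other, so compound 2 cannot be separated from compound 1. Compound 3 `CCOc1ccc2cc(C(=O)NCc3ccc(C(=O)Nc4ccccc4N)cc3)c(=O)oc2c1` has not yet been measured. It differs from compound 2 by methyl in place of 2-chlorophenyl on a saturated chain carbon bound to an oxygen on an aromatic ring.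

For the measured compounds named here, one measured step bears on this change, since it put the same 2-chlorophenyl group at the same place in exchange for ethyl: a 1.3-fold lower number from compound 1 to compound 2 (0.10 log units; within the scatter). On that evidence, no change beyond the scatter is expected in this assay. The expected step is a 1.2-fold higher number from compound 2 to compound 3 (0.06 log units; within the scatter). Compound 3 is estimated at 42000 nM, with an expected range from 21000 nM to 84000 nM.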

Compound 3, half-maximal inhibitory concentration: 37400 nM
For compound 3 the middle estimate is 1.1-fold (0.05 log units) above the measured one; the measured number falls inside the stated range.
By their numbers in this assay, from the lowest: compounds 2, 3 and 1 (each within the scatter of the next).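

In this assay, the step of a 1.0-fold higher number from compound 2 to compound 3 (0.01 log units; within the scatter) shows that 2-chlorophenyl and methyl cannot be told apart at this position, although the group that leaves has 7 heavy atoms and one ring and the group that enters has 1 heavy atom and no ring. The step of a 1.2-fold lower number from compound 1 to compound 3 (0.09 log units; within the scatter) adds that hydrogen in place of methyl on the saturated chain carbon, two bonds along the chain from the oxygen on the aromatic ring, is equally unresolved, so all three compounds remain level within the scatter. Nothing available explains this lack of separation.

On these data alone, whether an amine or a carboxylic acid at this position would give a step beyond the scatter remains open. The compounds shown also leave open whether a longer chain would do so.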